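The source may report more compounds than this note shows. Statements on the series, on what has been measured and on what is new or still open speak of the compounds shown alone.

Measured in a functional assay on SEM cells (Homo sapiens) for cytotoxicity, with a stated time of 72 h; on this read-out higher numbers stand for an effect only at larger amounts of compound and lower numbers for an effect already at smaller amounts (all three values are limits):
- Compound 1 `C=C[C@@](C)(/C=C/c1ccc(OS(=O)(=O)C(F)(F)F)cc1)CCC=C(C)C` gives > 36600 nM
- Compound 2 `C=C[C@@](C)(/C=C/c1ccc(OS(=O)(=O)c2ccc(C)cc2)cc1)CCC=C(C)C` gives > 43400 nM
- Compound 3 `C=C[C@@](C)(/C=C/c1ccc(O)cc1)CCC(O)C(C)(C)O` gives > 36600 nM

Compound 3 has only a limit, > 36600 nM, and no number. For the measured compounds named here, no compound here has a readable value, as the limit of > 36600 nM in this assay, at which 2 of the 3 values shown sit, and the limit of > 43400 nM in this assay, at which 1 of the 3 values shown sits, show. Compound 4 `C=C[C@@](C)(/C=C/c1ccc(O)cc1)CC/C=C/C#N` differs from compound 3 as follows: 2-cyanoethenyl in place of 1,2-dihydroxy-2-methylpropyl on a saturated chain carbon, three bonds along the chain from two double-bonded chain carbons. Going by the values given here, the only measured step, a step that the two limits leave unreadable from compound 1 to compound 2, concerns a different group and gives no size to carry over. A modest step toward smaller amounts in this assay is therefore expected, though another limit is quite possible. The expected step is an at least 1.4-fold lower number from compound 3 to compound 4 (0.16 log units; that floor lies within the scatter). For compound 4 the estimated value is 25000 nM, with an expected range from 8000 nM to 40000 nM.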

Compound 4, half-maximal effective concentration: > 36600 nM
Compound 4 ended at the assay's limit (the forecaster's own chance of this, stated with the estimate: 55%); middle value at least 1.4-fold (0.16 log units) away from the limit.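

In this assay compound 3 gives > 36600 nM, a limit. For the compounds shown here, compound 4 gives > 36600 nM, also a limit, so no step between compound 3 and compound 4 can be read. The compounds shown leave open whether any of them reaches a readable value, and so how any change of group bears on the read-out.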